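Ether side chains at the tolerated limit

A few compounds are considered here, and "the series" means these few. Any claim that something is new, unique, unknown or untested is made for them only; others in the source may bear on it.

compound 1 `Nc1nc(OCC(F)(F)F)c2ncn(/C=C3/CC3(CO)CO)c2n1` gives > 20000 nM
compound 2 `C=CCOc1nc(N)nc2c1ncn2/C=C1/CC1(CO)CO` gives > 20000 nM
compound 3 `CCOc1nc(N)nc2c1ncn2/C=C1/CC1(CO)CO` gives > 20000 nM

In an ADME assay on Akata cells (Homo sapiens) for cytotoxicity, with a stated time of 7 days (a higher number here means that more compound is tolerated, a lower number that less compound is tolerated), compound 3 gives > 20000 nM as a limit and not a number. Compound 3 has no readable rank in the series, which stands entirely on the limit of > 20000 nM in this assay, at which 3 of the 3 values shown sit, without a single number.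

Compound 4 `COCCOc1nc(N)nc2c1ncn2/C=C1/CC1(CO)CO` differs from compound 3 by methoxy in place of hydrogen on a saturated chain carbon, two bonds along the chain from an oxygen on an aromatic ring on the shared core, which turns ethoxy into 2-methoxyethoxy.

The steps a step that the two limits leave unreadable from compound 1 to compound 3 and a step that the two limits leave unreadable from compound 2 to compound 3 and a step that the two limits leave unreadable from compound 1 to compound 2 bear on this change, since each falls on a saturated chain carbon bound to an oxygen on an aromatic ring. None of them has a size that can be read. They show only that trifluoromethyl, vinyl and methyl there all leave the compound at a limit.

The expected change is a step that the limit leaves unreadable from compound 3 to compound 4 and no step beyond the scatter is foreseen in this assay in either direction. That expectation rests on compound 3 with > 20000 nM as its limit and on the two other compounds sitting at the same limit. For compound 4 the estimated half-maximal cytotoxic concentration is 25000 nM with an expected range from 10000 nM to 60000 nM and a report as a limit again is the likely outcome.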

Compound 4, half-maximal cytotoxic concentration: > 20000 nM
Compound 4 ended at the assay's limit; the forecaster's own chance of this, stated with the estimate: 85%; the middle value lies beyond the limit too.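

In this assay compound 4 gives > 20000 nM, a limit and not a number. Going by these compounds alone, no step among compound 1, compound 2, compound 3 and compound 4 can be read, since all four stand at one limit: the limit of > 20000 nM in this assay, at which 4 of the 4 values shown sit. The compounds shown leave open where the half-maximal cytotoxic concentration of any of these four ether side chains actually lies.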